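Shortening the amide chain on a shared core

The compounds below may be only part of what the source reports. "The series", "measured", "known", "first", "only" and "open" are said of these compounds alone.

Among the compounds with values here, compound 2 `CCCCC(=O)Nc1cc(Oc2ccc(Nc3nccc4[nH]cc(-c5ccc(F)cc5)c(=O)c34)cc2F)ccn1` is one of two compounds measured in a functional assay on MKN-45 cells (Homo sapiens) for antiproliferative activity, read by MTT assay, with a stated time of 72 h, tested at 10 uM (a higher number here means more inhibition at the concentration tested (going by the name of the read-out), a lower number less inhibition), where compound 2 gives 62.7%. Compound 1 `O=C(Nc1cc(Oc2ccc(Nc3nccc4[nH]cc(-c5ccc(F)cc5)c(=O)c34)cc2F)ccn1)C1CCC1` gives 52.8% in this assay, and the step of a number 9.9 percentage points higher from compound 1 to compound 2 (within the scatter) separates them, so compound 2 stands within the scatter of compound 1 rather than apart from it. Compound 3 `CCCC(=O)Nc1cc(Oc2ccc(Nc3nccc4[nH]cc(-c5ccc(F)cc5)c(=O)c34)cc2F)ccn1` has not yet been measured. It differs from compound 2 by hydrogen in place of methyl on a saturated chain carbon, three bonds along the chain from a carbonyl carbon, so the butyl becomes a propyl on the amide carbonyl. Within the data shown here, the only measured step, a number 9.9 percentage points higher from compound 1 to compound 2 (within the scatter), exchanged a cyclobutyl for a butyl on a carbonyl carbon and stayed within the scatter, so the number in this assay was level across that change. The step to compound 3 is therefore expected to be small, a number 4.7 percentage points lower from compound 2 to compound 3 (within the scatter), with no direction beyond the scatter. Compound 3 is estimated at 58%, between 45% and 70%.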

Compound 3, a percentage reported as inhibition, at one concentration (the size of the read-out at that concentration, not a potency): 64.6%
Compound 3: middle estimate off by 6.6 percentage points, on the low side, and the stated range covers the measured number.
By their numbers in this assay, from the lowest: compounds 1, 2 and 3 (each within the scatter of the next, the first and the last beyond it).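

In this assay the change from butyl to propyl on the amide carbonyl gives a number 1.9 percentage points higher from compound 2 to compound 3 (within the scatter) and so leaves the number level: at this place, three bonds along the chain from a carbonyl carbon, the methyl can give way to hydrogen without a change that can be told from the scatter. Within the data shown here, replacing the cyclobutyl of compound 1 with propyl gives a number 11.8 percentage points higher from compound 1 to compound 3 (beyond the scatter) and is the first step in this small set to be printed as beyond the scatter, though only modestly. Nothing available bears on the reason for either step.

The compounds shown leave open whether the number stays level if the chain on the carbonyl is cut further to an ethyl. They also leave open how an amine at the end of the propyl chain would read at this single concentration.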